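Compound 3: a chlorothiophene in place of chlorophenyl

The source may hold more compounds than are shown below. What is called first, only, known or untested is meant among the compounds shown, and "the series" means these compounds.

compound 1 `O=C(Nc1ccc(N2CCNCC2)cc1)c1ccc(-c2ccccc2Cl)o1` gives 15000 nM
compound 2 `O=C(Nc1ccc(N2CCNCC2)cc1)c1ccc(-c2ccc(Cl)cc2Cl)o1` gives 8100 nM

Among the measured compounds shown here, in an ADME assay on SW1353 cells (Homo sapiens) for cytotoxicity, read by a luciferase reporter, with a stated time of 30 min (on this read-out lower numbers stand for higher toxicity in this test and higher numbers for lower toxicity in this test), compound 1 and compound 2 lie within the scatter of each other, and no other compound has been measured. Compound 3 `O=C(Nc1ccc(N2CCNCC2)cc1)c1ccc(-c2ccc(Cl)s2)o1` is still unmeasured and carries 5-chlorothiophen-2-yl in place of 2-chlorophenyl (5-chlorothiophen-2-yl in place of 2-chlorophenyl on an aromatic carbon). For the measured compounds named here, the only measured step, a chloro in place of hydrogen on an aromatic carbon (a 1.9-fold lower number from compound 1 to compound 2 (0.27 log units; within the scatter)), bears on this loosely. Going by the values given here, no measured step exchanges the ring itself, so no change beyond the scatter is expected. The estimated step is small (a 1.5-fold lower number from compound 1 to compound 3 (0.18 log units; within the scatter)). Compound 3 is estimated at 10000 nM within an expected range (4500 nM to 22000 nM).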

Compound 3, half-maximal cytotoxic concentration: > 20000 nM
Compound 3 ended at the assay's limit; the forecaster's own chance of this, stated with the estimate: 10%; middle value at least 2.0-fold (0.30 log units) away from the limit.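

In this assay compound 3 stands at a limit, not at a number: the limit of > 20000 nM in this assay, at which 1 of the 3 values shown sits. With 5-chlorothiophen-2-yl in place of 2-chlorophenyl, the result is an at least 1.3-fold higher number from compound 1 to compound 3 (0.12 log units; that floor lies within the scatter), so no change beyond the scatter can be claimed for this exchange. With the same group in place of 2,4-dichlorophenyl, the result is an at least 2.4-fold higher number from compound 2 to compound 3 (0.39 log units; beyond the scatter), which shows that the aromatic ring at this place can be exchanged without a sign of higher toxicity in this test. From the compounds shown here alone, the true value of compound 3 remains open. So does the effect of an amine or a carboxylic acid in place of the chloro on the 5-chlorothiophen-2-yl group.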